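This account rests on a few compounds, and the source may have more. Where it says the series, first, only, none or still open, it means among the compounds named here.

Measured compounds:
compound 1, `N=C(N)c1ccc(-c2ccc(-c3cc(Cl)cc(Cl)c3)s2)cc1` — in a functional assay on Malme-3M cells (Homo sapiens) for inhibition, read by sulforhodamine B assay, with a stated time of 48 h (a lower number here means a stronger inhibitor of growth, a higher number a weaker inhibitor of growth), compound 1 gives "not determined" (no result reported)
compound 2, `N=C(N)c1ccc(-c2ccc(-c3ccc(Cl)cc3)s2)cc1F` — this assay: 490 nM

For the measured compounds named here, compound 2 holds the only number in this assay; compound 1 was run but gave no reported value, so compound 2 cannot be placed against anything else. No step between two measured compounds exists here, and no cause can be drawn from the data for any difference.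

The next compound is compound 3, `COc1ccc(-c2ccc(-c3ccc(C(=N)N)c(F)c3)s2)cc1`. It differs from compound 2 in one place: methoxy in place of chloro on an aromatic carbon. The change is small in counted atoms, adding one hydrogen-bond acceptor and no ring.

Going by the values given here, with no measured step of this kind to lean on, the expectation for compound 3 is a step within the usual scatter, leaning slightly weaker, so that a 1.4-fold higher number from compound 2 to compound 3 (0.15 log units; within the scatter) is expected to be modest. Compound 3 is estimated at 700 nM, with a range of 250 nM to 2500 nM.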

Compound 3, concentration for 50% growth inhibition: 2150 nM
Compound 3: middle estimate off by 3.1-fold (0.49 log units), on the low side; measured number inside the range.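

Methoxy in place of chloro on an aromatic carbon, para to a large group, gives a 4.4-fold higher number from compound 2 to compound 3 (0.64 log units; beyond the scatter) in this assay and thereby provides the first readable step in the series. This position therefore responds to the exchange beyond the usual scatter, with chloro the better of the two groups compared here. The step comes from a single pair, and the exchange changes several counted features at once, so it cannot be assigned to the loss of chlorine, the added heavy atom or the added hydrogen-bond acceptor; no measurement shown here bears on the reason.

Still open, going by these compounds, is how an amine, a carboxylic acid or a longer alkoxy chain would fare at this place. Also open, on these data alone, is whether the same exchange gives a step of similar size on a core without the fluoro group.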